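The source may hold more compounds than are shown below. What is called first, only, known or untested is meant among the compounds shown, and "the series" means these compounds.

Among the measured compounds shown here, compound 2 `Nc1ncnc2c1c(-c1cc(C3CC3)on1)nn2C1CCCCC1` is the one compound of the three that gives a number in an assay on TT cells for inhibition of proto-oncogene tyrosine-protein kinase receptor Ret variant C634W (Homo sapiens), read by MTT assay, with a stated time of 10 days; a lower number here means a stronger inhibitor of growth, a higher number a weaker inhibitor of growth: compound 2 gives 290 nM. Compound 1 `CC(C)n1nc(-c2cc(C3CCCCC3)on2)c2c(N)ncnc21` reaches only a limit of this assay, giving > 10000 nM. Compound 3 `CC(C)n1nc(-c2cc(-c3ccccc3)on2)c2c(N)ncnc21` likewise reaches only a limit, giving > 10000 nM. For the measured compounds named here, the single measured step, a step that the two limits leave unreadable from compound 1 to compound 3, cannot be read in size because of the limit of > 10000 nM in this assay, at which 2 of the 3 values shown sit. Compound 4 `Cn1nc(-c2cc(C3CC3)on2)c2c(N)ncnc21` differs from compound 2 in one place: methyl in place of cyclohexyl on an aromatic nitrogen. Going by the values given here, the measured step changes the group on an aromatic carbon, not the group on the aromatic nitrogen, so no measured step bears on this change, and any expectation rests on compound 2 alone. With no guide from the measured pairs, the expected outcome is a step of a 5.2-fold higher number from compound 2 to compound 4 (0.71 log units; beyond the scatter), in the direction of weaker growth inhibition, held with wide uncertainty. Compound 4 is therefore estimated at 1500 nM, within a range from 300 nM to 10000 nM.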

Compound 4, concentration for 50% growth inhibition: 3510 nM
Beside the measured number, compound 4's estimate is 2.3-fold (0.37 log units) below it; the range from low to high includes it.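

Among the compounds shown here, replacing cyclohexyl with methyl on the aromatic nitrogen gives a 12-fold higher number from compound 2 to compound 4 (1.08 log units; beyond the scatter) in this assay and is the first step in this set whose size can be read. For the compounds shown here, it shows that this nitrogen is a place where the choice of group matters: with the 5-cyclopropyl-1,2-oxazol-3-yl group held fixed, the cyclohexyl ring of compound 2 goes with clearly stronger growth inhibition than the single carbon of compound 4. Going by these compounds alone, the earlier step, on an aromatic carbon, cannot be read in size, so this is the only change with a measured size here.

Within the data shown here, with only two groups compared at this nitrogen, it remains open where an ethyl chain or a piperidine ring would fall in this assay. As far as these compounds go, it is also open whether the same change would have a similar effect with cyclohexyl or phenyl in place of the cyclopropyl group.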